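A few compounds are considered here, and "the series" means these few. Any claim that something is new, unique, unknown or untested is made for them only; others in the source may bear on it.

Measured in a functional assay on HCT-116 cells (Homo sapiens) for cytotoxicity, with a stated time of 3 days; on this read-out lower numbers stand for stronger inhibition and higher numbers for weaker inhibition:
compound 1 `Ic1nc2ccccc2o1`: > 40000 nM
compound 2 `C#CCNC(=O)c1csc(C#C)n1`: 19200 nM

Compound 1 gives only a limit, not a number: > 40000 nM.

Compound 3 `Brc1nc2ccccc2o1` has not yet been measured. It differs from compound 1 in one place: bromo in place of iodo on an aromatic carbon. Among the measured compounds shown here, no measured pair of compounds shows such an exchange. In this assay no step beyond the usual scatter is expected in either direction, and another limit reading would not be surprising. Compound 3 is estimated at 35000 nM, with an expected range of 15000 nM to 80000 nM.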

Compound 3, half-maximal inhibitory concentration: > 40000 nM
Compound 3: a limit, no number (the forecaster's own chance of this, stated with the estimate: 55%); middle value at least 1.1-fold (0.05 log units) from the limit.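

No step can be read from compound 1 to compound 3, as both give only a limit, not a number: the limit of > 40000 nM in this assay, at which 2 of the 3 values shown sit. From the compounds shown here alone, whether bromo in place of iodo changes cytotoxicity at all, and by how much, stays open.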